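Working notes: aryl exchange from compound 3 to compound 4

The source may report more compounds than this note shows. Statements on the series, on what has been measured and on what is new or still open speak of the compounds shown alone.

Of the compounds shown here, three sharing one core have been read in a functional assay on the whole organism (strain Kunming) with Mus musculus as the target, with a stated time of 0.5 h; on this read-out higher numbers stand for an effect only at larger amounts of compound and lower numbers for an effect already at smaller amounts. Compound 1 `COc1cc(OC)c(OC)cc1/C=C/COC(=O)/C=C/c1ccccc1C(F)(F)F` gives > 200 mg/kg, which is a limit of the assay and not a number. Compound 2 `COc1cc(OC)c(OC)cc1/C=C/COC(=O)/C=C/c1cccc(Br)c1` gives > 200 mg/kg, also a limit. Among the compounds with values here, compound 3 `COc1cc(OC)c(OC)cc1/C=C/COC(=O)/C=C/c1ccccc1Cl` gives 150 mg/kg, the only actual number in the set.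

Compound 4 `COc1cc(OC)c(OC)cc1/C=C/COC(=O)/C=C/c1ccc(F)cc1` has yet to be measured in this assay. The change is 4-fluorophenyl in place of 2-chlorophenyl on a double-bonded chain carbon bound to a double-bonded chain carbon.

Within the data shown here, three measured steps bear on this change, all of them exchanges on the same aromatic part. The first is an at least 1.3-fold lower number from compound 1 to compound 3 (0.12 log units; that floor lies within the scatter). The second is an at least 1.3-fold lower number from compound 2 to compound 3 (0.12 log units; that floor lies within the scatter). The third is a step that the two limits leave unreadable from compound 1 to compound 2. Both readable steps give only a floor, and neither shows a size beyond the scatter. Among the measured compounds shown here, none of the measured compounds carries 4-fluorophenyl, so the set gives no firm direction for this exchange. The expectation is therefore a 1.1-fold higher number from compound 3 to compound 4 (0.03 log units; within the scatter), with no step beyond the scatter expected. A reported limit also remains a likely outcome, given the results for compound 1 and compound 2. For compound 4 the estimated value is 160 mg/kg, with an expected range of 80 mg/kg to 320 mg/kg.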

Compound 4, dose for half-maximal effect: 167 mg/kg
The estimate for compound 4 lay 1.0-fold (0.02 log units) below the measured number; low and high end bracket the measured number.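

In this assay, the exchange at this place gives a 1.1-fold higher number from compound 3 to compound 4 (0.05 log units; within the scatter), so 2-chlorophenyl and 4-fluorophenyl, the two aryl groups here with actual numbers, cannot be told apart. Each of the other two steps starts from a limit and not a number, and they read as an at least 1.1-fold lower number from compound 2 to compound 4 (0.07 log units; that floor lies within the scatter) and an at least 1.1-fold lower number from compound 1 to compound 4 (0.07 log units; that floor lies within the scatter), so compound 4 cannot be separated from compound 1 or compound 2 by more than the scatter on this evidence. The true size of these two steps therefore stays unreadable, and a ranking of all four aryl groups at this place is still out of reach: the limit of > 200 mg/kg in this assay, at which 2 of the 4 values shown sit.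

The compounds shown leave open whether any aryl group at this place can move the number beyond the scatter, for instance a phenyl carrying an amine or a carboxylic acid in place of the halogen. On these data alone, all four compounds share one core and one ester, so it also stays open how an amide in place of the ester, or a longer chain between the ester and the aryl group, would read.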